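The source may hold more compounds than are shown below. What is called first, only, known or untested is meant among the compounds shown, and "the series" means these compounds.

Compound 3 `Cc1nn(-c2ncnc3nc[nH]c23)c2c1C(C(=O)NCc1ccccc1)CC(=O)N2` stands highest of the three compounds measured in a functional assay on HEK293 cells for agonist activity at G-protein coupled receptor 39 (Homo sapiens), read by scintillation proximity assay and inositol phosphate accumulation, with a stated time of 75 min; on this read-out higher numbers stand for an effect only at larger amounts of compound and lower numbers for an effect already at smaller amounts: compound 3 gives 2930 nM, while compound 1 `Cc1nn(-c2ncnc3nc[nH]c23)c2c1C(OCCc1ccccc1)CC(=O)N2` gives 40 nM and compound 2 `Cc1nn(-c2ncnc3nc[nH]c23)c2c1C(OCc1ccc(C(C)C)cc1)CC(=O)N2` gives 1690 nM. Compound 4 `Cc1nn(-c2ncnc3nc[nH]c23)c2c1C(OCc1ccc(C#N)cc1)CC(=O)N2` differs from compound 3 in one place: (4-cyanobenzyl)oxy in place of benzylcarbamoyl on a saturated ring carbon. Among the compounds with values here, two measured steps bear on this change. The first is a 73-fold higher number from compound 1 to compound 3 (1.86 log units; beyond the scatter), a large worsening on leaving phenethyloxy for benzylcarbamoyl. The second is a 42-fold higher number from compound 1 to compound 2 (1.63 log units; beyond the scatter), showing that a chain with an oxygen and a 4-isopropylphenyl also falls far behind phenethyloxy. The new (4-cyanobenzyl)oxy chain is closer in kind to that of compound 2, so a moderate step toward lower numbers is expected, a 4.2-fold lower number from compound 3 to compound 4 (0.62 log units; beyond the scatter). Compound 4 is estimated at 700 nM, within a range from 120 nM to 4000 nM.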

Compound 4, half-maximal effective concentration: 60 nM
For compound 4 the middle estimate is 12-fold (1.07 log units) above the measured one, and the stated range ends above it.
By their numbers in this assay, from the lowest: compounds 1 and 4 (each within the scatter of the next); then compounds 2 and 3 (each within the scatter of the next).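

At this saturated ring carbon, (4-cyanobenzyl)oxy in place of benzylcarbamoyl gives a 49-fold lower number from compound 3 to compound 4 (1.69 log units; beyond the scatter) and so recovers nearly all that the amide-linked chain gave up. The group on the aromatic carbon counts as well: cyano in place of isopropyl gives a 28-fold lower number from compound 2 to compound 4 (1.45 log units; beyond the scatter) even though the oxygen link stays the same. The 4-cyanophenyl chain and the benzyl chain of the phenethyloxy group give a 1.5-fold higher number from compound 1 to compound 4 (0.18 log units; within the scatter) and stand level here. From the compounds shown here alone, whether an amine or a carboxylic acid on that aromatic carbon, or a longer chain, would hold this level stays open. Nothing measured here explains these steps.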